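Furan-2-yl for 3-methoxyphenyl at the aromatic carbon

This account rests on a few compounds, and the source may have more. Where it says the series, first, only, none or still open, it means among the compounds named here.

Compound 1 `COc1cccc(-c2sc(N)c(C(=O)c3ccc(Cl)cc3)c2CC(C)(C)C)c1` in an assay on CHO cells for displacement of a labelled ligand from adenosine receptor A3 (Homo sapiens), read by scintillation counting, tested at 10 uM (a lower number here means less inhibition, a higher number more inhibition at the concentration tested (going by the name of the read-out)), gives 1%. It stands level with compound 2 `COc1ccc(-c2sc(N)c(C(=O)c3ccc(Cl)c(Cl)c3)c2CC(C)(C)C)cc1`, which gives 1%, the two together being the lowest of the three numbers, and compound 3 `COc1ccc(-c2sc(N)c(C(=O)c3ccc(C)cc3)c2CC(C)(C)C)cc1` with 5% lies within the scatter of both. Going by the values given here, the only measured step, a number 4 percentage points higher from compound 2 to compound 3 (within the scatter), concerns the aryl on the carbonyl carbon, not the aromatic carbon of the shared core. Compound 4 `CC(C)(C)Cc1c(-c2ccco2)sc(N)c1C(=O)c1ccc(Cl)cc1` differs from compound 1 by furan-2-yl in place of 3-methoxyphenyl on an aromatic carbon. Among the compounds with values here, no measured step bears on this position, and all three numbers so far are small. Compound 4 is therefore expected to show no step beyond the scatter, a number 2 percentage points higher from compound 1 to compound 4 (within the scatter). The estimate for compound 4 is 3%, between -8% and 15%.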

Compound 4, a percentage reported as inhibition, at one concentration (the size of the read-out at that concentration, not a potency): 1%
Beside the measured number, compound 4's estimate is 2 percentage points above it, and the stated range covers the measured number.
By their numbers in this assay, from the lowest: compounds 1, 2, 4 and 3 (each within the scatter of the next).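

Going by these compounds alone, the exchange gives no change at the digits printed from compound 1 to compound 4 (within the scatter) in this assay, the first reading at the aromatic carbon next to the ring sulfur. A five-membered aromatic ring with 1 hetero atom thus serves there no differently from 3-methoxyphenyl, so swapping one of these aromatic rings for the other does not raise the number at the concentration tested. No available evidence accounts for this result. Still open, as far as these compounds go, is whether an amine or a carboxylic acid at this aromatic carbon, rather than an aromatic ring, would raise the number.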